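The source may report more compounds than this note shows. Statements on the series, on what has been measured and on what is new or still open speak of the compounds shown alone.

The measured compounds and their values in an assay on cells for inhibition of Voltage-dependent T-type calcium channel subunit alpha-1H (Homo sapiens), read by FLIPR and calcium flux, with stated times of 600 s and 300 s; on this read-out lower numbers stand for stronger inhibition and higher numbers for weaker inhibition:
compound 1 `NCCCOc1ccc(CNc2nc3ccc(Oc4ccc(O)cc4)cc3s2)cc1` gives 300000 nM
compound 2 `N=C(N)NCCCOc1ccc(CNc2nc3ccc(Oc4cccc(C(F)(F)F)c4)cc3s2)cc1` gives 270000 nM
compound 3 `N=C(N)NCCCOc1ccc(CNc2nc3ccc(Oc4ccc(F)cc4)cc3s2)cc1` gives 288000 nM

Compound 3 stands second highest of the three numbers in this assay, but all three lie within the scatter of one another, so no order among them can be read. Among the compounds with values here, the one single-point step on record, a 1.1-fold higher number from compound 2 to compound 3 (0.03 log units; within the scatter), concerns the aryl ether and is within the scatter.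

Compound 4 `NCCCOc1ccc(CNc2nc3ccc(Oc4ccc(F)cc4)cc3s2)cc1` differs from compound 3 by a hydrogen atom in place of a group of 3 heavy atoms (1 carbon, 2 nitrogen; no ring), on an amine nitrogen. Within the data shown here, no measured step bears directly on this change: compound 1 also carries the amine rather than the guanidine, but it differs from compound 3 in the aryl ether as well, and its value and that of compound 3 show the same level. With nothing pointing elsewhere, compound 4 is expected to show a 1.0-fold higher number from compound 3 to compound 4 (0.00 log units; within the scatter), that is, no step beyond the scatter. The estimate for compound 4 is 290000 nM, within 150000 nM to 600000 nM.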

Compound 4, half-maximal inhibitory concentration: 688000 nM
Compound 4: middle estimate off by 2.4-fold (0.38 log units), on the low side, outside the stated range (above it).
By their numbers in this assay, from the lowest: compounds 2, 3 and 1 (each within the scatter of the next); then compound 4.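

Holding the 4-fluorophenyl ether fixed, the group on the amine nitrogen does register in this assay: a hydrogen atom in its place gives a 2.4-fold higher number from compound 3 to compound 4 (0.38 log units; beyond the scatter), a modest step beyond the scatter. Among the compounds with the free amine, the aromatic substituent also registers, with fluoro in place of hydroxy on an aromatic carbon giving a 2.3-fold higher number from compound 1 to compound 4 (0.36 log units; beyond the scatter), whereas the one step on record among the guanidines, a different aromatic change, stayed within the scatter. Nothing available explains either step.

The compounds shown leave open whether an acetyl group or a methyl group on the amine nitrogen would fall nearer compound 3 or compound 4. They also leave open whether fluoro and hydroxy would differ on the guanidine series as they do with the free amine.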